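Aryl swap on the amide side chain of compound 1

This account rests on a few compounds, and the source may have more. Where it says the series, first, only, none or still open, it means among the compounds named here.

compound 1 `COc1cccc(CCC(=O)Nc2nc3ccccc3c(=O)s2)c1` — 225 nM
compound 2 `O=C(CCCc1ccc(Cl)c(Cl)c1)Nc1nc2ccccc2c(=O)s1` — > 1000 nM
compound 3 `COc1cccc(/C=C/CC(=O)Nc2nc3ccccc3c(=O)s2)c1` — >= 1000 nM

Within the data shown here, in an assay on CHO cells for displacement of a labelled ligand from adenosine receptor A2b (Homo sapiens), read by scintillation counting, with a stated time of 75 min (on this read-out lower numbers stand for stronger inhibition and higher numbers for weaker inhibition), compound 1 gives 225 nM, the only outright number in the set. Compound 2 returns a limit of this assay rather than a number, > 1000 nM (the limit of > 1000 nM in this assay, at which 1 of the 3 values shown sits). Compound 3 likewise returns a limit rather than a number, >= 1000 nM (the limit of >= 1000 nM in this assay, at which 1 of the 3 values shown sits). Among the measured compounds shown here, compound 2 and compound 3 each differ from compound 1 in more than one place, so neither limit defines a step against compound 1, and no pair of measured compounds differing in a single place is available.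

Compound 4 `O=C(CCc1ccccc1Br)Nc1nc2ccccc2c(=O)s1` keeps the shared core and the three-carbon amide chain of compound 1 and differs in one place: 2-bromophenyl in place of 3-methoxyphenyl on a saturated chain carbon, two bonds along the chain from a carbonyl carbon. For the measured compounds named here, with no measured single-place step to anchor on, the expectation rests on compound 1 alone. A change of aryl substituent of this kind is expected to move the inhibition constant only modestly, if at all, so the step from compound 1 to compound 4 is estimated as a slight weakening, a 1.8-fold higher number from compound 1 to compound 4 (0.25 log units; within the scatter), close to the scatter of repeated measurements. Compound 4 is therefore expected to give about 400 nM in this assay, within a range of 120 nM to 1500 nM.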

Compound 4, inhibition constant: > 1000 nM
Compound 4 gave a limit, no number; the forecaster's own chance of this, stated with the estimate: 25%; at least 2.5-fold (0.39 log units) between middle value and limit.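

In this assay compound 4 returns a limit and not a number, > 1000 nM. Among these compounds, replacing 3-methoxyphenyl with 2-bromophenyl on a saturated chain carbon, two bonds along the chain from a carbonyl carbon, gives the first single-place step, an at least 4.4-fold higher number from compound 1 to compound 4 (0.64 log units; beyond the scatter), so this aryl swap is not silent at this position and the change lies beyond the scatter. The reading of compound 4 also joins the series' values at the assay limit, leaving compound 1 as the only compound here with an outright number: the limit of > 1000 nM in this assay, at which 2 of the 4 values shown sit.

The step has only a lower bound, and because the swap removes the methoxy group and brings in the bromine together, the pair cannot separate the loss of one from the arrival of the other, or either from the ring position. A plain phenyl group without a substituent at the same chain end would divide this step into its two parts, while an amine or a carboxylic acid on that ring would test whether this position tolerates anything beyond the 3-methoxyphenyl group of compound 1.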